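The source may hold more compounds than are shown below. What is called first, only, known or untested is meant among the compounds shown, and "the series" means these compounds.

Working notes on the series. Compound 1 `CCOC(=O)CNC(=O)NCc1ccc(C(=O)N2CCCCc3ccccc32)cc1C` gives 140 nM in a functional assay on HEK293 cells for agonist activity at Vasopressin V2 receptor (Homo sapiens), read by a luciferase reporter and cAMP accumulation; on this read-out higher numbers stand for an effect only at larger amounts of compound and lower numbers for an effect already at smaller amounts. Compound 2 `Cc1cc(C(=O)N2CCCCc3ccccc32)ccc1CNC(=O)N1CCC[C@@H]1C(=O)N(C)C` gives 380 nM in this assay. Going by the values given here, the one measured step, a 2.7-fold higher number from compound 1 to compound 2 (0.43 log units; beyond the scatter), exchanges the whole group on the carbonyl carbon. Among the compounds with values here, on the numbers so far compound 2 stands highest of the two, with compound 1 the nearest at a lower number, a gap that exceeds the scatter.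

Compound 3 `Cc1cc(C(=O)N2CCCCc3ccccc32)ccc1CNC(=O)N1CC(=O)C[C@H]1C(=O)N(C)C` differs from compound 2 by 2-(dimethylcarbamoyl)-4-oxopyrrolidin-1-yl in place of 2-(dimethylcarbamoyl)pyrrolidin-1-yl on a carbonyl carbon. Within the data shown here, no measured step alters the five-membered ring itself; the only step, a 2.7-fold higher number from compound 1 to compound 2 (0.43 log units; beyond the scatter), swaps one group on the carbonyl carbon for another and gives no guide to a change within that ring. The expectation for compound 3 therefore rests on the number for compound 2 alone. For compound 3 a step of a 1.3-fold higher number from compound 2 to compound 3 (0.12 log units; within the scatter) in this assay is expected, a shift not beyond the scatter, with a wide range to cover the lack of a guiding step. Compound 3 is estimated at 500 nM in this assay, with a range of 150 nM to 1700 nM.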

Compound 3, half-maximal effective concentration: 27 nM
Estimate against measurement, compound 3: 19-fold (1.27 log units) above; measured number below the stated range.
By their numbers in this assay, from the lowest: compound 3; then compound 1; then compound 2.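

In this assay, going by these compounds alone, the five-membered ring itself proves sensitive to change: the 4-oxo group of 2-(dimethylcarbamoyl)-4-oxopyrrolidin-1-yl, in place of 2-(dimethylcarbamoyl)pyrrolidin-1-yl on the carbonyl carbon, gives a 14-fold lower number from compound 2 to compound 3 (1.15 log units; beyond the scatter), a large step, whereas the earlier compounds showed only a modest change on exchange of the whole group at this carbonyl carbon. The ring-bearing group also now falls on the other side of ((ethoxycarbonyl)methyl)amino, with a 5.2-fold lower number from compound 1 to compound 3 (0.71 log units; beyond the scatter) as the step, so the order seen with compound 1 and compound 2 reverses once the ring carries the 4-oxo group. No measurement at hand accounts for this gain, and its cause remains unassigned.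

The compounds shown leave open whether the gain is specific to the ring ketone, as a hydroxyl group, an amine or two fluorine atoms in place of the 4-oxo group would test. They also leave open how much the dimethylcarbamoyl group contributes alongside the 4-oxo group, a question that a carboxylic acid or an unsubstituted primary amide in its place would address.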